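Trimming One Methyl from a Fatty Acid Receptor Agonist

This account rests on a few compounds, and the source may have more. Where it says the series, first, only, none or still open, it means among the compounds named here.

Three measured compounds share one core and differ in the group attached to it. Compound 1 `CC#CC(CC(=O)O)c1ccc(OCc2ccn3cc(-c4ccccc4)nc3c2)cc1` carries a plain phenyl and gives 1260 nM in an assay on isolated protein for agonist activity at Free fatty acid receptor 1 (Homo sapiens); on this read-out higher numbers stand for an effect only at larger amounts of compound and lower numbers for an effect already at smaller amounts. Compound 2 `CC#CC(CC(=O)O)c1ccc(OCc2ccn3cc(-c4ccc(C)cc4C)nc3c2)cc1` carries a 2,4-dimethylphenyl and gives 503 nM in this assay. Compound 3 `CC#CC(CC(=O)O)c1ccc(OCc2ccc3nc(-c4ccccc4C)cn3c2)cc1` carries a 2-methylphenyl on a differently arranged core and gives 389 nM in this assay. Among these three, compound 2 stands second; its gap to compound 3 lies within the scatter, whereas the change from phenyl to 2,4-dimethylphenyl gave a 2.5-fold lower number from compound 1 to compound 2 (0.40 log units; beyond the scatter).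

Compound 4 `CC#CC(CC(=O)O)c1ccc(OCc2ccn3cc(-c4ccc(C)cc4)nc3c2)cc1` has not yet been measured. It differs from compound 2 by hydrogen in place of methyl on an aromatic carbon, so one of the two methyl groups of compound 2 is taken away. For the measured compounds named here, the only measured step that bears on this is the one from plain phenyl to both methyl groups at once, which gave a 2.5-fold lower number from compound 1 to compound 2 (0.40 log units; beyond the scatter). Because a 2.5-fold lower number from compound 1 to compound 2 (0.40 log units; beyond the scatter) came from adding both methyl groups together, taking one of them away is expected to return part of that change, giving a somewhat higher number in this assay. The step is expected to be a 1.6-fold higher number from compound 2 to compound 4 (0.20 log units; within the scatter). Compound 4 is estimated at 800 nM, with a range from 350 nM to 1800 nM.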

Compound 4, half-maximal effective concentration: 618 nM
Beside the measured number, compound 4's estimate is 1.3-fold (0.11 log units) above it; low and high end bracket the measured number.
By their numbers in this assay, from the lowest: compounds 3, 2 and 4 (each within the scatter of the next); then compound 1.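

Taking away the methyl ortho to a large group, which turns 2,4-dimethylphenyl into 4-methylphenyl, gives a 1.2-fold higher number from compound 2 to compound 4 (0.09 log units; within the scatter) in this assay, so in this pair that methyl makes no difference that can be told from the scatter. The other comparison is from plain phenyl to 4-methylphenyl, a change of a single methyl, and it gives a 2.0-fold lower number from compound 1 to compound 4 (0.31 log units; beyond the scatter); the earlier step from phenyl to 2,4-dimethylphenyl therefore did not need both methyl groups to produce a change that can be read. Nothing measured here says why one methyl gives a readable step while taking away the other does not.

The compounds shown leave open what the methyl ortho to a large group would do on its own on the core of compound 1, without the methyl of 4-methylphenyl. They also leave open whether a different group in the place of that remaining methyl, such as a methoxy group, a chlorine atom or an amine, would keep, enlarge or lose the step seen with the methyl.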